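Nitro for Chloro on the Sulfonyl Aryl Ring

This account rests on a few compounds, and the source may have more. Where it says the series, first, only, none or still open, it means among the compounds named here.

Going by the values given here, compound 2 `CCCCC(CC)C(=O)Nc1ccc2ccn(Cc3ccc(C(=O)NS(=O)(=O)c4ccc(Cl)cc4)cc3OC)c2c1` stands highest of the two compounds measured so far. In a functional assay (trachea) for antagonist activity, with Cavia porcellus as the target (on this read-out lower numbers stand for lower potency and higher numbers for higher potency (the scale is a negative logarithm)), compound 2 gives 7.8, while compound 1 `CCCCC(CC)C(=O)Nc1ccc2ccn(Cc3ccc(C(=O)NS(=O)(=O)c4ccc(OC)cc4)cc3OC)c2c1` gives 7.4. Among the compounds with values here, the single measured step, a number 0.40 log units higher from compound 1 to compound 2 (beyond the scatter), is the only guide available. Compound 3 `CCCCC(CC)C(=O)Nc1ccc2ccn(Cc3ccc(C(=O)NS(=O)(=O)c4ccc([N+](=O)[O-])cc4)cc3OC)c2c1` has not yet been measured; it differs from compound 2 by nitro in place of chloro on an aromatic carbon. This change sits at the same place where the measured step exchanged methoxy for chloro, so that step bears on it, although it compares different groups. Within the data shown here, that step was modest, and with only one such comparison there is no basis for expecting a large move in either direction. The step of no change at the digits printed from compound 2 to compound 3 (within the scatter) is therefore estimated to fall within the scatter. Compound 3 is expected to give about 7.8 in this assay, with a range from 7.3 to 8.3.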

Compound 3, negative logarithm of the antagonist equilibrium constant: 7.7
The estimate for compound 3 lay 0.10 log units above the measured number; the measured number falls inside the stated range.
By their numbers in this assay, from the lowest: compounds 1, 3 and 2 (each within the scatter of the next, the first and the last beyond it).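

In this assay, the change from 4-chlorophenyl to 4-nitrophenyl gives a number 0.10 log units lower from compound 2 to compound 3 (within the scatter) and so shows that this position takes nitro, with its hydrogen-bond acceptors, in place of chloro without a change that can be told from the scatter. The change from methoxy to nitro gives a number 0.30 log units higher from compound 1 to compound 3 (within the scatter) at the same place, whereas the change from methoxy to chloro gave a number 0.40 log units higher from compound 1 to compound 2 (beyond the scatter) and so only the chloro and methoxy compounds stand apart, while the nitro compound lies within the scatter of both. Nothing measured here accounts for these numbers.

Going by these compounds, whether an amine or a carboxylic acid on this aromatic carbon would keep the number in this range remains open. So does the outcome with unsubstituted phenyl, or with a longer chain such as butoxy in the same place.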